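The source may hold more compounds than are shown below. What is called first, only, known or untested is meant among the compounds shown, and "the series" means these compounds.

Compound 1 `Nc1nc(N)c2c(-c3ccccc3)cn([C@@H]3O[C@H](CO)[C@@H](O)[C@H]3O)c2n1` in a functional assay on K562 cells (Homo sapiens), read by MTT assay, with a stated time of 72 h; a higher number here means a weaker inhibitor, a lower number a stronger inhibitor: > 20000 nM
Compound 2 `COc1nc(N)nc2c1c(-c1ccoc1)cn2[C@@H]1O[C@H](CO)[C@@H](O)[C@H]1O` in this assay: > 20000 nM
Compound 3 `Cc1nc(N)c2c(-c3ccoc3)cn([C@@H]3O[C@H](CO)[C@@H](O)[C@H]3O)c2n1` in this assay: > 20000 nM

Each of the three values is a limit of the assay and not a number. For compound 1 the value is a limit. For compound 2 the value is a limit. For compound 3 the value is likewise a limit, so compound 3 stands nowhere in particular among the three: all of them sit together at the limit of > 20000 nM in this assay, at which 3 of the 3 values shown sit, and no order among them can be read from these data.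

Compound 4 `Nc1nc(N)c2c(-c3ccoc3)cn([C@@H]3O[C@H](CO)[C@@H](O)[C@H]3O)c2n1` has not been measured in this assay. It differs from compound 3 by amino in place of methyl on an aromatic carbon; amino in place of methyl on an aromatic carbon, sitting between two ring nitrogen atoms of the six-membered aromatic ring with two nitrogen in the fused system. Among the measured compounds shown here, no measured pair differs in one place, so no step size is known. Given that compound 1 and compound 3 both rest at the limit of > 20000 nM in this assay, at which 3 of the 3 values shown sit, the expected step from compound 3 to compound 4, a step that the limit leaves unreadable from compound 3 to compound 4, is none that this assay could register. Compound 4 is expected to give 30000 nM, between 10000 nM and 100000 nM, most likely again as a limit.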

Compound 4, half-maximal inhibitory concentration: > 20000 nM
Compound 4: no number, only a limit; the forecaster's own chance of this, stated with the estimate: 80%; the middle value is on the limit's open side.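

In this assay compound 4 gives > 20000 nM, which is a limit and not a number. No step from compound 1, compound 2 or compound 3 to compound 4 can be read, because all four compounds rest together: the limit of > 20000 nM in this assay, at which 4 of the 4 values shown sit.

The compounds shown leave open how these four compounds rank against one another and which change to the shared core, if any, would give a readable value.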